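The source may report more compounds than this note shows. Statements on the series, on what has been measured and on what is new or still open speak of the compounds shown alone.

Measured compounds:
compound 1 `NC(=O)c1c(NC(=O)c2ccccc2Cl)sc2c1CCN(C(=S)Nc1ccccc1)C2` — 15600 nM
compound 2 `NC(=O)c1c(NC(=O)c2ccccc2Cl)sc2c1CCN(C(=S)Nc1ccccc1I)C2` — 2630 nM
compound 3 `Cc1ccccc1NC(=S)N1CCc2c(sc(NC(=O)c3ccccc3Cl)c2C(N)=O)C1` — 11700 nM

In a functional assay on MKN-74 cells (Homo sapiens) for antiproliferative activity, with a stated time of 24 h (on this read-out lower numbers stand for stronger inhibition and higher numbers for weaker inhibition), compound 3 stands second highest of the three numbers. Compound 3 and compound 1 lie within the scatter of each other, as the step of a 1.3-fold lower number from compound 1 to compound 3 (0.12 log units; within the scatter) shows; the gap to compound 2 is larger, as shown by a 4.4-fold higher number from compound 2 to compound 3 (0.65 log units; beyond the scatter).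

Compound 4 `NC(=O)c1c(NC(=O)c2ccccc2Cl)sc2c1CCN(C(=S)Nc1ccc(C(F)(F)F)cc1)C2` differs from compound 3 in one place: 4-(trifluoromethyl)phenyl in place of 2-methylphenyl on an amide-type nitrogen. Going by the values given here, no measured step introduces a trifluoromethyl group on this phenyl ring, so the measured steps bear on the change only indirectly. The step of a 5.9-fold lower number from compound 1 to compound 2 (0.77 log units; beyond the scatter) shows that a substituent other than methyl on this phenyl ring can lower the number modestly, while a 1.3-fold lower number from compound 1 to compound 3 (0.12 log units; within the scatter) shows that methyl produces nothing beyond the scatter. For compound 4 a modest lowering at most is therefore expected, with wide uncertainty, estimated as a 1.8-fold lower number from compound 3 to compound 4 (0.26 log units; within the scatter). Compound 4 is expected to give 6500 nM, within the range 2200 nM to 19000 nM.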

Compound 4, half-maximal inhibitory concentration: 7090 nM
Compound 4: middle estimate off by 1.1-fold (0.04 log units), on the low side, and the stated range covers the measured number.
By their numbers in this assay, from the lowest: compound 2; then compounds 4, 3 and 1 (each within the scatter of the next, the first and the last beyond it).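

In this assay, adding trifluoromethyl to the phenyl ring gives a 2.2-fold lower number from compound 1 to compound 4 (0.34 log units; beyond the scatter), so iodo is no longer the only substituent on this phenyl ring to move the number beyond the scatter, whereas methyl did not. The step of a 1.7-fold lower number from compound 3 to compound 4 (0.22 log units; within the scatter) leaves 4-(trifluoromethyl)phenyl and 2-methylphenyl unresolved on this amide-type nitrogen, while 2-iodophenyl remains apart, with a 2.7-fold higher number from compound 2 to compound 4 (0.43 log units; beyond the scatter). No evidence on hand accounts for these steps.

Among the compounds shown, no single group appears at two places on the phenyl ring, so the effect of the group and that of its place on the ring cannot be separated. Going by these compounds, how an amine or a carboxylic acid on this ring, or a longer alkyl chain in place of the phenyl ring, would read remains open.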